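Removing One Trifluoromethyl Group From Compound 1

The compounds below may be only part of what the source reports. "The series", "measured", "known", "first", "only" and "open" are said of these compounds alone.

Measured compounds:
compound 1 `COc1cc(-c2nn(-c3cccc(NC(=O)Nc4cc(C(F)(F)F)cc(C(F)(F)F)c4)c3)cc2-c2ccncc2)ccc1Cl` — > 50000 nM
compound 2 `COc1cc(-c2nn(-c3cccc(NC(=O)c4cccc(C(F)(F)F)c4)c3)cc2-c2ccncc2)ccc1Cl` — > 50000 nM
compound 3 `O=C(Nc1cccc(-n2cc(-c3ccncc3)c(-c3ccc(Cl)c(O)c3)n2)c1)Nc1ccc(Cl)c(Cl)c1` — > 32500 nM

In a functional assay on SR cells (Homo sapiens) for inhibition, read by sulforhodamine B assay, with a stated time of 48 h (a higher number here means that more compound is tolerated, a lower number that less compound is tolerated), compound 1 gives > 50000 nM, and this is a limit of the assay rather than a number. Compound 2 gives > 50000 nM in this assay, again a limit. Compound 3 gives > 32500 nM, also a limit. Compound 1 therefore stands where two of the three measured compounds sit, at the limit of > 50000 nM in this assay, at which 2 of the 3 values shown sit, while the third sits at the limit of > 32500 nM in this assay, at which 1 of the 3 values shown sits. Among the compounds with values here, none of the three compounds has a resolved value, so no measured step between them can be drawn, and no ordering among them is known.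

Compound 4 `COc1cc(-c2nn(-c3cccc(NC(=O)Nc4cccc(C(F)(F)F)c4)c3)cc2-c2ccncc2)ccc1Cl` is the next compound to be measured. It differs from compound 1 by hydrogen in place of trifluoromethyl on an aromatic carbon. Within the data shown here, no step between measured compounds in this study bears on such a change. Since compound 1, compound 2 and compound 3 all remain at a limit of this assay, the step from compound 1 to compound 4 is expected to produce no change beyond the scatter, with compound 4 also expected to sit at a limit. The estimate for compound 4 in this assay is 60000 nM, within 30000 nM to 150000 nM, which corresponds to an expected step that the limit leaves unreadable from compound 1 to compound 4.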

Compound 4, concentration lethal to 50% of the cells: > 50000 nM
Compound 4: no number, only a limit (the forecaster's own chance of this, stated with the estimate: 85%); the middle value does not contradict the limit.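

In this assay compound 4 gives > 50000 nM, which is a limit, so the steps to it from compound 1 and from compound 2, themselves both at a limit, cannot be read. The compounds shown leave open whether replacing a trifluoromethyl group with hydrogen changes the value at all.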